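The compounds below may be only part of what the source reports. "The series", "measured", "known", "first", "only" and "open" are said of these compounds alone.

Compound 3 `O=C1C(Nc2ccc(CO)cc2)=CC(=O)c2ncncc21` is an aryl amine on a shared core; in a functional assay on BXPC-3 cells (Homo sapiens) for cytotoxicity, read by MTT assay, with a stated time of 72 h (a lower number here means a stronger inhibitor, a higher number a weaker inhibitor), compound 3 gives 5700 nM, the highest of the two plain numbers here. Its nearest neighbour is compound 1 `O=C1C(Nc2ccc(-c3ccc(F)cc3)cc2)=CC(=O)c2ncncc21`, which gives 4400 nM. Compound 2 `NS(=O)(=O)c1ccc(NC2=CC(=O)c3ncncc3C2=O)cc1` gives only a limit, > 10000 nM, in this assay (the limit of > 10000 nM in this assay, at which 1 of the 3 values shown sits). Compound 4 `O=C1C(Nc2ccc(-c3ccccc3)cc2)=CC(=O)c2ncncc21` is the next step: phenyl in place of hydroxymethyl on an aromatic carbon. The relevant measured step runs the other way, from 4-fluorophenyl to hydroxymethyl, and was a 1.3-fold higher number from compound 1 to compound 3 (0.11 log units; within the scatter), so replacing hydroxymethyl by a ring close to that of compound 1 is expected to give no change beyond the scatter, perhaps a slightly lower number. Compound 4 is therefore estimated at 4500 nM, with a range from 2000 nM to 10000 nM, meaning an expected step of a 1.3-fold lower number from compound 3 to compound 4 (0.10 log units; within the scatter).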

Compound 4, half-maximal inhibitory concentration: 500 nM
For compound 4 the middle estimate is 9.0-fold (0.95 log units) above the measured one; the measured number lies below the stated range.
By their numbers in this assay, from the lowest: compound 4; then compounds 1 and 3 (each within the scatter of the next). At a limit, above all of these: compound 2.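

A phenyl at this position gives an 11-fold lower number from compound 3 to compound 4 (1.06 log units; beyond the scatter), and in place of sulfamoyl it gives an at least 20-fold lower number from compound 2 to compound 4 (1.30 log units; beyond the scatter). Having a ring here does not settle the number, since a single atom changes it: with hydrogen in place of fluoro, the result is an 8.8-fold lower number from compound 1 to compound 4 (0.94 log units; beyond the scatter). Compound 2 is held only at a limit, so its step is a floor: the limit of > 10000 nM in this assay, at which 1 of the 4 values shown sits.

As far as these compounds go, whether the loss seen with fluoro belongs to that atom alone, or would also come with a chloro, a methoxy or an amine on the phenyl ring, stays open.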